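One Number and a Single Oxygen

The source may hold more compounds than are shown below. What is called first, only, known or untested is meant among the compounds shown, and "the series" means these compounds.

Four compounds share one core, but the record for them is thin. In a functional assay on MM1.S cells (Homo sapiens) for cytotoxicity, read by MTT assay, with a stated time of 48 h (a lower number here means a stronger inhibitor, a higher number a weaker inhibitor), compound 3 `CC(C)(C)C(=O)NN=C1C(Cl)=C(Cl)C(Cl)=C1Cl` gives 2000 nM. Within the data shown here, that is the only number available, so compound 3 cannot be ranked as strong or weak against any relative. Compound 1 `C#CCOC(=O)NN=C1C(Cl)=C(Cl)C(Cl)=C1Cl` offers no comparison, as its entry reads "not determined" (no result reported). Compound 2 `C#CC(C)(C)OC(=O)NN=C1C(Cl)=C(Cl)C(Cl)=C1Cl` is no more helpful, with an entry of "not determined" (no result reported).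

The next compound to be measured is compound 4 `CC(C)(C)OC(=O)NN=C1C(Cl)=C(Cl)C(Cl)=C1Cl`. It keeps the shared core and changes one group relative to compound 3: tert-butoxy in place of tert-butyl on a carbonyl carbon. In words, tert-butoxy stands in place of tert-butyl on a carbonyl carbon.

Among the measured compounds shown here, no step between measured compounds exists to show how this assay responds to a change of this kind. The data therefore give no reason to favour either direction. The expectation rests only on compound 3 at 2000 nM, and the range is kept wide to reflect that. The expected step of no change at the digits printed from compound 3 to compound 4 (within the scatter) is not thought to go beyond the usual scatter. For compound 4 the estimated value is 2000 nM, with an expected range from 650 nM to 6000 nM.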

Compound 4, half-maximal inhibitory concentration: 600 nM
For compound 4 the middle estimate is 3.3-fold (0.52 log units) above the measured one, and the stated range ends above it.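

In this assay, among these compounds, replacing tert-butyl with tert-butoxy on a carbonyl carbon gives a 3.3-fold lower number from compound 3 to compound 4 (0.52 log units; beyond the scatter), the first evidence that this position responds to a change at all, and here the response is towards a stronger inhibitor. By count, the exchange adds one oxygen and one hydrogen-bond acceptor while keeping the four carbons, so the step shows that a change this small can move the number beyond the usual scatter, though a single pair establishes no trend. Nothing measured here accounts for the shift, and the reason for it remains unknown.

From the compounds shown here alone, compound 1 and compound 2 have no number, so their steps to the other compounds cannot be read, and it remains unknown whether the alkyne-bearing groups they carry on the same oxygen would keep, lose or extend what tert-butoxy gives. Among the compounds shown here, also open is how this assay would respond if an amine or a longer chain stood on the same carbonyl carbon, which would help show whether the oxygen itself matters or only this particular group.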